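Halogen swap on a mercapto-acrylic acid calpain inhibitor

The source may hold more compounds than are shown below. What is called first, only, known or untested is meant among the compounds shown, and "the series" means these compounds.

Of the compounds shown here, three have been measured in an assay on isolated protein for inhibition of Calpain-1 catalytic subunit (Sus scrofa), read by FRET; a lower number here means a stronger inhibitor, a higher number a weaker inhibitor. Compound 1 `O=C(O)/C(S)=C/c1ccccc1Cl` gives 11900 nM, compound 2 `O=C(O)/C(S)=C/c1ccccc1I` gives 29600 nM, and compound 3 `O=C(O)/C(S)=C/c1cccc(I)c1` gives 4300 nM. The change chloro in place of iodo on an aromatic carbon produced a 2.5-fold lower number from compound 2 to compound 1 (0.40 log units; beyond the scatter). Compound 3 stands lowest of the three; the difference between its core and that of compound 2 is not broken down here.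

Compound 4 `O=C(O)/C(S)=C/c1cccc(Cl)c1` differs from compound 3 by chloro in place of iodo on an aromatic carbon. This is the same kind of change as that from compound 2 to compound 1, but the place differs: there the group sat ortho to a group of 6 heavy atoms, here meta to a group of 6 heavy atoms. Resting on that earlier step, compound 4 is expected to show a 2.2-fold lower number from compound 3 to compound 4 (0.33 log units; beyond the scatter). Compound 4 is therefore estimated at 2000 nM, between 700 nM and 6000 nM.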

Compound 4, half-maximal inhibitory concentration: 4200 nM
Compound 4: the middle estimate sits 2.1-fold (0.32 log units) below what was measured, within the range that was stated.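

The change of chloro in place of iodo on the core of compound 3 gave a 1.0-fold lower number from compound 3 to compound 4 (0.01 log units; within the scatter), so this pair cannot be told apart. The step does not differ measurably from the earlier one, so the series gives no sign that the change behaves differently on the two cores: the same change on two cores in this assay, a 2.5-fold lower number (0.40 log units; beyond the scatter) from compound 2 to compound 1 and a 1.0-fold lower number (0.01 log units; within the scatter) from compound 3 to compound 4, 2.4-fold (0.39 log units) apart, within the scatter of two such steps Nor does this show that the change carries over unchanged, as one step lies beyond the scatter, the other within it, and two pairs are few.

The compounds shown leave open how a fluoro, bromo, methyl or nitrile would compare in the same place. They also leave open whether the same steps would hold with an amide in place of the carboxylic acid.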